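Indole Substituent Swap in a Hydroxamic Acid Series

The source may hold more compounds than are shown below. What is called first, only, known or untested is meant among the compounds shown, and "the series" means these compounds.

Compound 1, `Cc1[nH]c2ccccc2c1C1=CCC(NCc2ccc(OCC(=O)NO)cc2F)CC1`: 912 nM
Compound 2, `COc1cc(OCC(=O)NO)ccc1CNCCn1cnc2ccccc21`: > 10000 nM

Among the compounds with values here, in a functional assay on MCF7 cells (Homo sapiens) for antiproliferative activity, with a stated time of 72 h (on this read-out lower numbers stand for stronger inhibition and higher numbers for weaker inhibition), compound 1 gives 912 nM, the only actual number among the two results. Compound 2 reaches only a limit of the assay, > 10000 nM, which is the limit of > 10000 nM in this assay, at which 1 of the 2 values shown sits. Compound 3, `O=C(COc1ccc(CNC2CC=C(c3c[nH]c4ccc(F)cc34)CC2)c(F)c1)NO`, differs from compound 1 in one place: 5-fluoro-1H-indol-3-yl in place of 2-methyl-1H-indol-3-yl on a double-bonded ring carbon. Within the data shown here, no measured pair shows how such a swap acts, so the expected change is a 1.1-fold higher number from compound 1 to compound 3 (0.04 log units; within the scatter), none beyond the usual scatter in this assay. Compound 3 is therefore estimated at 1000 nM, most likely between 300 nM and 3500 nM.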

Compound 3, half-maximal inhibitory concentration: 1420 nM
Compound 3: middle estimate off by 1.4-fold (0.15 log units), on the low side; low and high end bracket the measured number.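

Putting 5-fluoro-1H-indol-3-yl in place of 2-methyl-1H-indol-3-yl gives, in this assay, a 1.6-fold higher number from compound 1 to compound 3 (0.19 log units; within the scatter) for this swap. This position on the double-bonded ring carbon therefore accepts either indole group, and the two compounds cannot be told apart on this read-out. No measurement shown gives a reason for this result.

On these data alone, the swap removes a methyl and adds a fluorine in one step, so the effect of each alone stays open. Also open, as far as these compounds go, is how a carboxylic acid or an amine on the indole would fare.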